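Amine variation on a shared core: allyl to 4-chlorobenzyl

This account rests on a few compounds, and the source may have more. Where it says the series, first, only, none or still open, it means among the compounds named here.

Measured compounds:
compound 1 `C=CCN(CCC)Cc1c(C(F)(F)F)nc2n(-c3c(C)cc(C)cc3C)c(Cl)cn12`: 4.5 nM
compound 2 `C=CCN(CC=C)Cc1c(C(F)(F)F)nc2n(-c3c(C)cc(C)cc3C)c(Cl)cn12`: 13 nM
compound 3 `CCN(CCC1CC1)Cc1c(C(F)(F)F)nc2n(-c3c(C)cc(C)cc3C)c(Cl)cn12`: 13 nM

In an assay on cells for displacement of a labelled ligand from corticotropin-releasing factor receptor 1 (Homo sapiens), with a stated time of 100 min (a lower number here means a stronger inhibitor, a higher number a weaker inhibitor), compound 1 gives the lowest number of the three measured compounds; both compound 2 and compound 3 lie beyond the scatter above it. The step of a 2.9-fold higher number from compound 1 to compound 2 (0.46 log units; beyond the scatter) and the step of a 2.9-fold higher number from compound 1 to compound 3 (0.46 log units; beyond the scatter) are of the same size, and compound 2 against compound 3 shows no change at the digits printed from compound 2 to compound 3 (within the scatter). Every change so far has been made on the amine substituents, and each move away from compound 1 has cost a modest amount.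

Compound 4 `CCCN(Cc1ccc(Cl)cc1)Cc1c(C(F)(F)F)nc2n(-c3c(C)cc(C)cc3C)c(Cl)cn12` differs from compound 1 as follows: 4-chlorophenyl in place of vinyl on a saturated chain carbon bound to an amine nitrogen. The measured steps bearing on this are the two above, both modest losses from compound 1 on the same amine. The new group is larger than anything tried so far, so a loss at least of that size is expected, with wide uncertainty. The expected step is a 4.4-fold higher number from compound 1 to compound 4 (0.65 log units; beyond the scatter). For compound 4 the estimate in this assay is 20 nM, with a range from 5 nM to 80 nM.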

Compound 4, inhibition constant: 28 nM
For compound 4 the middle estimate is 1.4-fold (0.15 log units) below the measured one; measured number inside the range.
By their numbers in this assay, from the lowest: compound 1; then compounds 2 and 3 (each within the scatter of the next); then compound 4.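

In this assay the 4-chlorobenzyl group in place of allyl, with the propyl chain kept, gives a 6.2-fold higher number from compound 1 to compound 4 (0.79 log units; beyond the scatter) and this loss is still classed as modest. Compounds 1, 2 and 3 carry only open chains or a cyclopropyl on this amine, whereas compound 4 shows that a six-membered aromatic ring of carbon only, bearing chlorine, can stand on a saturated chain carbon bound to an amine nitrogen with binding still in the nanomolar range. Nothing available explains the size of this step.

From the compounds shown here alone, it remains open whether the loss follows the aromatic ring or the chlorine. A plain benzyl group, a 4-fluorobenzyl group or a pyridylmethyl group on the same propyl amine would separate these two readings.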